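The compounds below may be only part of what the source reports. "The series", "measured", "known", "first", "only" and "open" are said of these compounds alone.

Measured compounds:
compound 1 `CCC(=O)N1CCCn2nc(COc3ccccc3)cc21` gives 48%
compound 2 `O=C(C1CC1)N1CCCn2nc(COc3ccccc3)cc21` gives 61%

Both were tested in a functional assay on HEK293 cells for positive allosteric modulation of metabotropic glutamate receptor 5 (Homo sapiens), read by calcium flux; on this read-out higher numbers stand for larger maximal responses and lower numbers for smaller maximal responses. Compound 2 stands highest of the two numbers; its nearest neighbour is compound 1, and the step of a number 13 percentage points higher from compound 1 to compound 2 (beyond the scatter) lies beyond the scatter. Within the data shown here, the only change on the shared core so far is the acyl group on the carbonyl carbon.

Compound 3 `O=C(c1ccccn1)N1CCCn2nc(COc3ccccc3)cc21` carries the next change at the same place: pyridin-2-yl in place of cyclopropyl on a carbonyl carbon. Among the measured compounds shown here, the one step that bears on it, a number 13 percentage points higher from compound 1 to compound 2 (beyond the scatter), was modest and came from a small change on the carbonyl carbon; a larger change at that position could go either way, so a small step is the expectation but not a confident one. Compound 3 is therefore estimated at 55%, with a range from 30% to 85%. This amounts to an expected step of a number 6 percentage points lower from compound 2 to compound 3 (within the scatter).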

Compound 3, largest response reached (reported as percent of maximum), in percent of the reference or control that the assay uses: 44%
For compound 3 the middle estimate is 11 percentage points above the measured one; the range from low to high includes it.
By their numbers in this assay, from the lowest: compounds 3 and 1 (each within the scatter of the next); then compound 2.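

In this assay the acyl position turns out to move the maximal response in both directions: pyridin-2-yl in place of cyclopropyl on the carbonyl carbon gives a number a number 17 percentage points lower from compound 2 to compound 3 (beyond the scatter) and so reverses the earlier gain. Pyridin-2-yl in place of ethyl gives a number 4 percentage points lower from compound 1 to compound 3 (within the scatter), so these two very different groups cannot be told apart on this read-out, and among the three compounds only the cyclopropyl group of compound 2 stands apart from the others. Nothing measured here offers an explanation for the loss that comes with this change.

The compounds shown leave open whether that loss belongs to the ring nitrogen or to the aromatic ring as such, a question a plain phenyl group on the carbonyl carbon would address. Also open, as far as these compounds go, is whether the higher response is peculiar to cyclopropyl or extends to other small rings such as cyclobutyl.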